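The source may report more compounds than this note shows. Statements on the series, on what has been measured and on what is new or still open speak of the compounds shown alone.

Working notes on the series. Three measured compounds share one core and differ only at the saturated amine on the chain: compound 1 `COc1cc2c(Oc3ccc(NC(=O)c4cn(-c5ccccc5)nn4)cc3F)ccnc2cc1OCCCN1CCCC1`, compound 2 `COc1cc2c(Oc3ccc(NC(=O)c4cn(-c5ccccc5)nn4)cc3F)ccnc2cc1OCCCN1CCCCC1` and compound 3 `COc1cc2c(Oc3ccc(NC(=O)c4cn(-c5ccccc5)nn4)cc3F)ccnc2cc1OCCCN1CCC(C)CC1`. In a functional assay on MKN-45 cells (Homo sapiens) for cytotoxicity, read by MTT assay, with a stated time of 72 h (on this read-out lower numbers stand for stronger inhibition and higher numbers for weaker inhibition), compound 1 gives 260 nM, compound 2 gives 100 nM and compound 3 gives 90 nM. The steps of a 2.6-fold lower number from compound 1 to compound 2 (0.41 log units; beyond the scatter) and a 2.9-fold lower number from compound 1 to compound 3 (0.46 log units; beyond the scatter) both lie beyond the scatter, whereas a 1.1-fold lower number from compound 2 to compound 3 (0.05 log units; within the scatter). Compound 3 therefore carries the lowest number of the three, but compound 2 stands within the scatter of it; only compound 1 is separated from it beyond the scatter.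

Compound 4 `COc1cc2c(Oc3ccc(NC(=O)c4cn(-c5c(C)cccc5C)nn4)cc3F)ccnc2cc1OCCCN1CCC(C)CC1` is the next member. It departs from compound 3 at the other end of the molecule: 2,6-dimethylphenyl in place of phenyl on an aromatic nitrogen. None of the three measured steps bears on this position; all of them concern the amine on the chain and leave the ring on the aromatic nitrogen untouched. For the measured compounds named here, there is thus no measured step from which a shift in this assay in either direction could be read, and the working expectation is a step that stays within the scatter. On that footing compound 4 is expected to give 110 nM, with a range from 40 nM to 320 nM. This expectation amounts to a 1.2-fold higher number from compound 3 to compound 4 (0.09 log units; within the scatter).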

Compound 4, half-maximal inhibitory concentration: 4310 nM
Beside the measured number, compound 4's estimate is 39-fold (1.59 log units) below it, outside the stated range (above it).
By their numbers in this assay, from the lowest: compounds 3 and 2 (each within the scatter of the next); then compound 1; then compound 4.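

In this assay, the ring on the aromatic nitrogen proves to be a far more sensitive position than the amine on the chain: a 48-fold higher number from compound 3 to compound 4 (1.68 log units; beyond the scatter) is much larger than the biggest step seen at the amine, a 2.9-fold lower number from compound 1 to compound 3 (0.46 log units; beyond the scatter). For the compounds shown here, the change adds only two methyl groups, taking phenyl with 6 heavy atoms to 2,6-dimethylphenyl with 8, and both groups have no hydrogen-bond donors, no hydrogen-bond acceptors and no net charge, so a large loss of inhibition here occurs with those counts unchanged. No measurement at hand accounts for the size of this step, so its cause remains unassigned.

The compounds shown leave open whether the loss needs both methyl groups or whether 2-methylphenyl, with a single methyl, would already give a step of this size, and whether 2,6-difluorophenyl, with fluorine atoms in place of the methyl groups, would behave in the same way. They also leave open whether the step keeps its size when the 4-methylpiperidin-1-yl group on the chain is replaced by piperidin-1-yl or pyrrolidin-1-yl.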